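A few compounds are considered here, and "the series" means these few. Any claim that something is new, unique, unknown or untested is made for them only; others in the source may bear on it.

Measured compounds and their numbers:

Compound 1 `O=c1c2[nH]c(Cc3cccs3)nc2n(Cc2ccco2)c(=O)n1CC1CC1` gives 347 nM in an assay on cell membranes for displacement of a labelled ligand from adenosine receptor A1 (Rattus norvegicus); a higher number here means a weaker inhibitor, a lower number a stronger inhibitor.
Compound 2 `C#CCn1c(=O)c2[nH]c(Cc3cccs3)nc2n(Cc2ccco2)c1=O` gives 219 nM in this assay .
Compound 3 `CSCCn1c(=O)c2[nH]c(Cc3c(F)cccc3F)nc2n(Cc2ccco2)c1=O` gives 200 nM in this assay .

Compound 1 carries the highest of the three numbers, but its step to compound 2, a 1.6-fold lower number from compound 1 to compound 2 (0.20 log units; within the scatter), is within the scatter, and the number of compound 3 is likewise within the scatter of that of compound 1, so the three compounds cannot be placed in any order of strength.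

The unmeasured compound 4 `Cn1c(Cc2cccs2)nc2c1c(=O)n(CC1CC1)c(=O)n2Cc1ccco1` differs from compound 1 by methyl in place of hydrogen on an aromatic nitrogen. Within the data shown here, no measured step bears directly on this change. Among the measured compounds shown here, the one step on record, a 1.6-fold lower number from compound 1 to compound 2 (0.20 log units; within the scatter), concerns a group on a chain carbon bound to an aromatic nitrogen, far from the ring nitrogen changed here, and compound 3 differs from compound 1 in two places at once, so it gives no separate reading of any single change. With nothing to anchor a direction, the expectation for compound 4 is a step of a 1.2-fold higher number from compound 1 to compound 4 (0.06 log units; within the scatter), meaning no shift beyond the scatter, but with a deliberately wide range to reflect the lack of a comparable step. Compound 4 is therefore estimated at 400 nM, with a range from 120 nM to 1500 nM.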

Compound 4, inhibition constant: 100 nM
For compound 4 the middle estimate is 4.0-fold (0.60 log units) above the measured one; measured number below the stated range.
By their numbers in this assay, from the lowest: compounds 4, 3, 2 and 1 (each within the scatter of the next, the first and the last beyond it).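

Methyl in place of hydrogen on this aromatic nitrogen gives a 3.5-fold lower number from compound 1 to compound 4 (0.54 log units; beyond the scatter) in this assay, the only step on record that lies beyond the scatter, though it is modest in size. Among these compounds, this shows that the number responds to a change at this ring nitrogen, something the earlier compounds could not show, as their numbers all lay within the scatter of one another. It also shows that, on this shared core, a hydrogen on this nitrogen is not required for a number of this size, yet nothing measured here explains the change.

From the compounds shown here alone, it remains open whether a longer chain on this nitrogen, such as ethyl or propyl, or a larger group such as benzyl, would lower the number further or raise it again. Going by these compounds, it is equally open whether the same methyl would give a similar step on compound 2 or compound 3, which differ from compound 1 elsewhere in the molecule.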